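Cyclohexyl for cyclopropyl on the ring nitrogen of compound 1

The source may report more compounds than this note shows. Statements on the series, on what has been measured and on what is new or still open speak of the compounds shown alone.

The study measured two compounds in an assay on Huh-7 cells for agonist activity at Bile acid receptor (Homo sapiens), read by a luciferase reporter; on this read-out higher numbers stand for an effect only at larger amounts of compound and lower numbers for an effect already at smaller amounts. Compound 1 `CC(C)c1onc(-c2c(Cl)cccc2Cl)c1COc1ccc(-c2nc3ccc(C(=O)O)cc3n2C2CC2)cc1` gives 16.5 nM in this assay, the higher of the two numbers recorded. Compound 2 `CCC(CC)n1c(-c2ccc(OCc3c(-c4c(Cl)cccc4Cl)noc3C(C)C)cc2Cl)nc2ccc(C(=O)O)cc21` gives 1.6 nM in this assay, and its number lies well beyond the scatter of compound 1; the two compounds differ in more than one place, so their values alone tell what the pair shows.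

Compound 3 `CC(C)c1onc(-c2c(Cl)cccc2Cl)c1COc1ccc(-c2nc3ccc(C(=O)O)cc3n2C2CCCCC2)cc1` has not yet been measured in this assay. It differs from compound 1 in a single position: cyclohexyl in place of cyclopropyl on an aromatic nitrogen. Within the data shown here, since no pair differing in only one place has been measured, the expected step from compound 1 to compound 3 is estimated at a 2.8-fold lower number from compound 1 to compound 3 (0.44 log units; beyond the scatter), a move toward a lower number that reaches beyond the scatter. On that basis compound 3 is expected to give about 6 nM in this assay, with a range from 1.5 nM to 25 nM.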

Compound 3, half-maximal effective concentration: 4.21 nM
Compound 3: the middle estimate sits 1.4-fold (0.15 log units) above what was measured, within the range that was stated.
By their numbers in this assay, from the lowest: compound 2; then compound 3; then compound 1.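

Among these compounds, replacing cyclopropyl with cyclohexyl on the aromatic nitrogen gives the first change in one place that can be read in this assay, with a 3.9-fold lower number from compound 1 to compound 3 (0.59 log units; beyond the scatter), so this position accepts the larger carbon ring without a move toward a higher number. The groups differ here in ring size and heavy-atom count, while both carry no hydrogen-bond donors or acceptors and no net charge. No measurement on hand gives a reason for the step.

The compounds shown leave open where cyclobutyl or cyclopentyl would fall relative to these two rings, and so whether the number follows ring size at all. They also leave open how a piperidine ring or a longer straight chain on the same nitrogen would read.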